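Phenethyl Ether Replaces Isopropylbenzyl Ether in a Pyrazolopyridinone Series

This account rests on a few compounds, and the source may have more. Where it says the series, first, only, none or still open, it means among the compounds named here.

Three compounds were examined in a functional assay on HEK293 cells for agonist activity at G-protein coupled receptor 39 (Homo sapiens), read by scintillation proximity assay and inositol phosphate accumulation, with a stated time of 75 min; on this read-out lower numbers stand for an effect already at smaller amounts and higher numbers for an effect only at larger amounts of compound. Compound 1 `Cc1cc(C)nc(-n2nc(C)c3c2NC(=O)CC3c2ccc(COc3cccc(Cl)c3)cc2)n1` gives 3000 nM in this assay. Compound 2 `Cc1nn(-c2ncnc3nc[nH]c23)c2c1C(OCc1ccc(C(C)C)cc1)CC(=O)N2`, which carries a 4-isopropylbenzyl ether on the shared core, gives 1690 nM. Compound 3 `Cc1nn(-c2ncnc3nc[nH]c23)c2c1C(C(=O)N(C)c1nccs1)CC(=O)N2`, where an amide takes the place of the ether, gives 3300 nM. Compound 2 holds the lowest of the three numbers, yet the gaps to compound 1 and to compound 3 both fall within the usual scatter of this assay, so no ranking of the three can be drawn from these values.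

The unmeasured compound 4 `Cc1nn(-c2ncnc3nc[nH]c23)c2c1C(OCCc1ccccc1)CC(=O)N2` is derived from compound 2 by a single change: benzyl in place of 4-isopropylphenyl on a saturated chain carbon bound to an oxygen on a saturated carbon. The ether side chain thus shrinks, and the same difference, cut one bond further out, reads 4-isopropylbenzyl to phenethyl.

Going by the values given here, no measured pair in this set isolates such a change, so the expectation rests on compound 2 alone. The author expects the step of a 1.8-fold higher number from compound 2 to compound 4 (0.25 log units; within the scatter) to be small, tending toward a higher number, and quite possibly not beyond the scatter. Compound 4 is therefore estimated at 3000 nM in this assay, with a plausible range from 1000 nM to 10000 nM.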

Compound 4, half-maximal effective concentration: 40 nM
Estimate against measurement, compound 4: 75-fold (1.88 log units) above; measured number outside the range, below it.
By their numbers in this assay, from the lowest: compound 4; then compounds 2, 1 and 3 (each within the scatter of the next).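

In this assay, the ether side chain on the shared core proves able to move the number sharply: benzyl in place of 4-isopropylphenyl on a saturated chain carbon bound to an oxygen on a saturated carbon gives a 42-fold lower number from compound 2 to compound 4 (1.63 log units; beyond the scatter). Compound 2 and compound 3 had stood within the scatter of each other, so the ether and the amide at this carbon had shown no separation, yet phenethyloxy in place of methyl(1,3-thiazol-2-yl)carbamoyl on a saturated ring carbon gives an 83-fold lower number from compound 3 to compound 4 (1.92 log units; beyond the scatter), so the particular ether matters more than the earlier pair suggested. Nothing available here accounts for the size of these steps.

The step from 4-isopropylbenzyl to phenethyl both removes the isopropyl group and moves the phenyl ring further out along the chain, and the compounds shown leave open which of the two carries the step; a plain benzyl ether or a 4-isopropylphenethyl ether on the same carbon would separate them. Also open, from the compounds shown here alone, is how far the chain can go, as with a 3-phenylpropyl ether, and whether a chloro or methoxy group on the phenethyl ring is tolerated.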